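The compounds below may be only part of what the source reports. "The series", "measured", "known", "first", "only" and "open" are said of these compounds alone.

The set holds three measured compounds. Compound 1 `COC(=O)c1cccc(NC(=O)c2cc3cc([N+](=O)[O-])ccc3o2)c1` gives 25 ug/mL in a physicochemical assay for solubility; on this read-out lower numbers stand for lower solubility and higher numbers for higher solubility. Compound 2 `COC(=O)c1ccc(NC(=O)c2cc3ccccc3s2)cc1` gives 20 ug/mL in this assay, and compound 3 `NC(=O)c1ccccc1NC(=O)c1ccc2ccccc2n1` gives 10 ug/mL. Compound 3 thus shows the lowest of the three numbers; its nearest neighbour is compound 2, whose number is higher by an amount that stays within the scatter, while compound 1 stands furthest away, with a number higher by a margin that lies beyond the scatter. Going by the values given here, none of the three compounds differs from another in one place only, so no single step between measured compounds can be read from these data.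

Compound 4 `NCc1ccccc1NC(=O)c1ccc2ccccc2n1` has not yet been measured. It differs from compound 3 in one place: aminomethyl in place of carbamoyl on an aromatic carbon. Among the compounds with values here, no measured pair shows this change, so what follows rests on the structural change alone and is an expectation, not a reading. The estimated step in this assay is a 4.0-fold higher number from compound 3 to compound 4 (0.60 log units; beyond the scatter), an upward move that would lie beyond the usual scatter. Compound 4 is accordingly expected to give 40 ug/mL in this assay, within an estimated range from 12 ug/mL to 150 ug/mL.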

Compound 4, solubility: 25 ug/mL
Estimate against measurement, compound 4: 1.6-fold (0.20 log units) above; the range from low to high includes it.
By their numbers in this assay, from the lowest: compounds 3, 2, 1 and 4 (each within the scatter of the next, the first and the last beyond it).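

In this assay, the set now holds its first step that can be read in one place, a 2.5-fold higher number from compound 3 to compound 4 (0.40 log units; beyond the scatter), so at this aromatic carbon, ortho to a large group, aminomethyl in place of carbamoyl goes with a modest upward move beyond the scatter. The earlier compounds shown here differed from one another in more than one place and could show nothing about this position, whereas here the change is confined to a single group. The counts of hydrogen-bond donors and acceptors are the same for the two groups and neither carries a net charge, while one oxygen and the double bond outside the aromatic rings leave; no measurement at hand accounts for the step.

This single step leaves open whether the move follows from the loss of the carbonyl or from the amine nitrogen, a question that hydroxymethyl, methyl or dimethylaminomethyl on the same aromatic carbon would help to separate. Going by these compounds, it also remains open how a carboxylic acid or a longer aminoethyl chain would read there, and whether the same change would carry over to another core.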